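This account rests on a few compounds, and the source may have more. Where it says the series, first, only, none or still open, it means among the compounds named here.

In a functional assay on the whole organism with Scenedesmus acutus as the target, with a stated time of 20 h (a lower number here means a stronger inhibitor, a higher number a weaker inhibitor), compound 1 `O=C(O)c1cc(N2C(=O)C3=C(CCCC3)C2=O)c(F)cc1Cl` gives 3160 nM. Compound 3 `CCOC(=O)c1cc(N2C(=O)C3=C(CCCC3)C2=O)ccc1Cl` gives 2140 nM, which lies within the scatter of compound 1. Compound 2 `O=C(O)c1cc(N2C(=O)C3=C(CCCC3)C2=O)ccc1Cl` reads > 100000 nM, which is a limit of the assay and not a number.

Compound 4 `CCCOC(=O)c1cc(N2C(=O)C3=C(CCCC3)C2=O)c(F)cc1Cl` differs from compound 1 by one change, propyl in place of hydrogen on an oxygen next to a carbonyl group, which turns carboxy into propoxycarbonyl. The closest measured precedent is an at least 46-fold lower number from compound 2 to compound 3 (1.66 log units; beyond the scatter), a large step beyond the scatter, with ethyl in place of hydrogen at that same kind of place. The fluoro kept in compound 4 also counts, as an at least 31-fold higher number from compound 1 to compound 2 (1.50 log units; beyond the scatter) is large too, and beyond the scatter. Starting from compound 1 at 3160 nM, the new change is expected to act in the same direction, towards a lower number, though the size of the ethyl step need not carry over to propyl. The expected result is a 16-fold lower number from compound 1 to compound 4 (1.20 log units; beyond the scatter). For compound 4 the estimated value is 200 nM, with an expected range of 25 nM to 1600 nM.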

Compound 4, half-maximal inhibitory concentration: 66.1 nM
Compound 4: middle estimate off by 3.0-fold (0.48 log units), on the high side, and the stated range covers the measured number.
By their numbers in this assay, from the lowest: compound 4; then compounds 3 and 1 (each within the scatter of the next). At a limit, above all of these: compound 2.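

Propyl in place of hydrogen on an oxygen next to a carbonyl group, which turns carboxy into propoxycarbonyl, gives a 48-fold lower number from compound 1 to compound 4 (1.68 log units; beyond the scatter) in this assay. The earlier step of this kind began at compound 2, whose reading is a limit and not a number: the limit of > 100000 nM in this assay, at which 1 of the 4 values shown sits. This new step has a measured number at both ends, so it gives an actual size for the change, and it shows the same direction in a compound that keeps the fluoro.

Compounds 3 and 4 differ in more than one place, so the part played by propyl as against ethyl cannot be separated here. On these data alone, how a longer chain such as butyl on that oxygen would read, or an amide in place of the ester, stays open.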